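Moving the trifluoromethyl group from compound 3 to compound 4

The compounds below may be only part of what the source reports. "The series", "measured", "known", "first", "only" and "open" are said of these compounds alone.

Measured in an ADME assay on HepG2 cells (Homo sapiens) for cytotoxicity, read by MTT assay, with a stated time of 72 h; a lower number here means that less compound is tolerated, a higher number that more compound is tolerated:
- compound 1 `O=[N+]([O-])c1c(CS(=O)(=O)c2ccccc2)nc2c(-c3cccc(F)c3)cc(Cl)cn12`: > 12500 nM
- compound 2 `O=[N+]([O-])c1c(CS(=O)(=O)c2ccccc2)nc2c(-c3ccc(F)cc3F)cc(Cl)cn12`: > 7800 nM
- compound 3 `O=[N+]([O-])c1c(CS(=O)(=O)c2ccccc2)nc2c(-c3ccc(C(F)(F)F)cc3)cc(Cl)cn12`: > 3900 nM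

Compound 3 stands at > 3900 nM, which is a limit and not a number. The entries for compound 1 and compound 2 are limits too, so no exact value exists in this series.

Compound 4 `O=[N+]([O-])c1c(CS(=O)(=O)c2ccccc2)nc2c(-c3ccccc3C(F)(F)F)cc(Cl)cn12` keeps the same atoms, joined differently: 2-(trifluoromethyl)phenyl in place of 4-(trifluoromethyl)phenyl on an aromatic carbon.

The closest measured changes are a step that the two limits leave unreadable from compound 1 to compound 3 and a step that the two limits leave unreadable from compound 2 to compound 3, with a step that the two limits leave unreadable from compound 1 to compound 2 alongside them. None gives a size, so no step beyond the scatter, in either direction, is expected in this assay. The expected change is a step that the limit leaves unreadable from compound 3 to compound 4. For compound 4 the estimated value is 5000 nM, with an expected range of 2500 nM to 12500 nM.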

Compound 4, half-maximal cytotoxic concentration: 22700 nM
The estimate for compound 4 lay 4.5-fold (0.66 log units) below the measured number; the whole stated range lies below it.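

In this assay, the steps to compound 4 from compound 1, compound 2 and compound 3 cannot be read: those three compounds carry limits, not numbers. The compounds shown leave open whether 2-(trifluoromethyl)phenyl in place of 4-(trifluoromethyl)phenyl changes the result at all.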